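Varying the Alkoxy Group on a Pyridine Antagonist Core

The compounds below may be only part of what the source reports. "The series", "measured", "known", "first", "only" and "open" are said of these compounds alone.

Three compounds share a core and differ only at one position on the aromatic ring. In an assay on CHO cells for antagonist activity at transient receptor potential cation channel subfamily V member 1 (Homo sapiens), read by FLIPR (on this read-out higher numbers stand for weaker inhibition and lower numbers for stronger inhibition), compound 1 `CC1CC(C)CN(c2nc(C(F)(F)Cl)ccc2CNC(=O)C(C)c2ccc(NS(C)(=O)=O)c(F)c2)C1` gives 1 nM. Compound 2 `CCCCCCOc1nc(C(F)(F)Cl)ccc1CNC(=O)C(C)c1ccc(NS(C)(=O)=O)c(F)c1` gives 0.8 nM in this assay, and compound 3 `CC(C)COc1nc(C(F)(F)Cl)ccc1CNC(=O)C(C)c1ccc(NS(C)(=O)=O)c(F)c1` gives 0.6 nM. The steps among them are small: a 1.3-fold lower number from compound 1 to compound 2 (0.10 log units; within the scatter), a 1.7-fold lower number from compound 1 to compound 3 (0.22 log units; within the scatter) and a 1.3-fold lower number from compound 2 to compound 3 (0.12 log units; within the scatter). Compound 3 holds the lowest of the three numbers, but each of its neighbours lies within the scatter of it, so no order among them can be claimed.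

Compound 4 `CC(C(=O)NCc1ccc(C(F)(F)Cl)nc1OCc1ccccn1)c1ccc(NS(C)(=O)=O)c(F)c1` differs from compound 3 by pyridin-2-yl in place of isopropyl on a saturated chain carbon bound to an oxygen on an aromatic ring. Among the measured compounds shown here, only the step of a 1.3-fold lower number from compound 2 to compound 3 (0.12 log units; within the scatter) touches the same carbon, and it was within the scatter; neither it nor the other two steps brings an aromatic ring into this place, so they give no direct guide to the size of the change. Since every variation seen so far at this position left the number within the scatter, compound 4 is expected to stay close, with an estimated 2.5-fold higher number from compound 3 to compound 4 (0.40 log units; beyond the scatter) and a value of 1.5 nM, between 0.4 nM and 6 nM.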

Compound 4, inhibition constant: 4.2 nM
Estimate against measurement, compound 4: 2.8-fold (0.45 log units) below; the range from low to high includes it.
By their numbers in this assay, from the lowest: compounds 3, 2 and 1 (each within the scatter of the next); then compound 4.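

Among the changes shown at this position, this is the only one that moves the number beyond the scatter in this assay (a 7.0-fold higher number from compound 3 to compound 4 (0.85 log units; beyond the scatter)) and the same holds against the other two compounds (a 5.3-fold higher number from compound 2 to compound 4 (0.72 log units; beyond the scatter)) (a 4.2-fold higher number from compound 1 to compound 4 (0.62 log units; beyond the scatter)). The place on a saturated chain carbon bound to an oxygen on an aromatic ring showed no readable difference between isopropyl and pentyl, yet it does respond to pyridin-2-yl, a six-membered aromatic ring with 1 hetero atom. Nothing available here accounts for this rise.

The compounds shown leave open whether the rise goes with the aromatic ring or with its nitrogen, which phenyl in the same place would separate. Pyridin-3-yl or pyridin-4-yl there would show whether the place of that nitrogen in the ring matters.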